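Second bromine on the propoxymethyl catechol core

A few compounds are considered here, and "the series" means these few. Any claim that something is new, unique, unknown or untested is made for them only; others in the source may bear on it.

Compound 1 `COCc1cc(O)c(O)c(Br)c1` is the reference of the set. In a functional assay on DLD-1 cells (Homo sapiens) for cytotoxicity, read by MTT assay, with a stated time of 96 h (on this read-out lower numbers stand for stronger inhibition and higher numbers for weaker inhibition), compound 1 gives 35300 nM, and compound 2 `COCc1cc(Br)c(O)c(O)c1Br` gives 7270 nM. The step between them, a 4.9-fold lower number from compound 1 to compound 2 (0.69 log units; beyond the scatter), follows one change: bromo in place of hydrogen on an aromatic carbon. Compound 3 `CCCOCc1cc(O)c(O)c(Br)c1` differs from compound 1 by ethyl in place of hydrogen on a saturated chain carbon bound to an oxygen on a saturated carbon; in this assay compound 3 gives 26300 nM, a step of a 1.3-fold lower number from compound 1 to compound 3 (0.13 log units; within the scatter).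

Compound 4 `CCCOCc1cc(O)c(O)c(Br)c1Br` has not been measured. It differs from compound 3 by bromo in place of hydrogen on an aromatic carbon. This is the same kind of change as that from compound 1 to compound 2, but the surroundings are not identical: in compound 2 the entering bromo is ortho to a hydroxy group, ortho to a methoxymethyl group and para to a bromo group, whereas in compound 4 it is ortho to a bromo group, ortho to a propoxymethyl group and para to a hydroxy group. Among the measured compounds shown here, the only precedent for the change occurs once, in the step from compound 1 to compound 2, so the expectation leans on that single step. Since the step of a 1.3-fold lower number from compound 1 to compound 3 (0.13 log units; within the scatter) is within the scatter, the core of compound 3 is taken to behave like that of compound 1. Compound 4 is therefore expected to show a step of about a 4.4-fold lower number from compound 3 to compound 4 (0.64 log units; beyond the scatter), with an estimated value of 6000 nM, plausibly between 2500 nM and 15000 nM.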

Compound 4, half-maximal inhibitory concentration: 12400 nM
The estimate for compound 4 lay 2.1-fold (0.32 log units) below the measured number; the range from low to high includes it.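

In this assay the entering bromo again lowers the number on the core with the propoxymethyl group, as a 2.1-fold lower number from compound 3 to compound 4 (0.33 log units; beyond the scatter) shows. Set beside the earlier step, this step differs from it by no more than the scatter of two such steps, so the change carries from the core of compound 1 to the core of compound 3 without a difference that can be read: the same change on two cores in this assay, a 4.9-fold lower number (0.69 log units; beyond the scatter) from compound 1 to compound 2 and a 2.1-fold lower number (0.33 log units; beyond the scatter) from compound 3 to compound 4, 2.3-fold (0.36 log units) apart, within the scatter of two such steps. Among the compounds shown here, this rests on only two pairs in a single cell assay, so it does not show that the step holds on other cores, and it cannot separate the part played by the different surroundings of the entering bromo in compound 2 and compound 4.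

As far as these compounds go, whether a chlorine or a methyl group at the same ring carbon would give a step like that of bromo remains open. Also open, from the compounds shown here alone, is whether the step survives on a core with a longer chain on the ether, or with an amine or a carboxylic acid in that chain.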